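Aryl swap on the shared core: cytotoxicity tolerance notes

This account rests on a few compounds, and the source may have more. Where it says the series, first, only, none or still open, it means among the compounds named here.

compound 1 `COc1nc(C(C)(C)C)ccc1[C@@H](c1ccccc1)[C@@](O)(CCN(C)C)c1cccc2ccccc12` — > 64 ug/mL
compound 2 `COc1nc(-c2ccccc2F)ccc1[C@@H](c1ccccc1)[C@@](O)(CCN(C)C)c1cccc2ccccc12` — "nd" (no result reported)
compound 3 `COc1nc(-c2ccsc2)ccc1[C@@H](c1ccccc1)[C@@](O)(CCN(C)C)c1cccc2ccccc12` — > 64 ug/mL
compound 4 `COc1nc(-c2ccc(C(F)(F)F)cc2)ccc1[C@@H](c1ccccc1)[C@@](O)(CCN(C)C)c1cccc2ccccc12` — not yet measured

In a toxicity assay on HeLa cells (Homo sapiens) for cytotoxicity (a higher number here means that more compound is tolerated, a lower number that less compound is tolerated), compound 1 reaches only a limit of the assay, > 64 ug/mL. Compound 2 has no result, "nd" (no result reported). Compound 3 likewise stops at a limit, > 64 ug/mL. Among the compounds with values here, the one step between measured compounds, a step that the two limits leave unreadable from compound 1 to compound 3, is therefore unreadable; two of the three entries sit at the limit of > 64 ug/mL in this assay, at which 2 of the 3 values shown sit, so compound 3 stands at the tolerated edge of what this assay resolves.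

Compound 4 differs by 4-(trifluoromethyl)phenyl in place of thiophen-3-yl on an aromatic carbon. Within the data shown here, no measured step gives a readable size for such an aryl swap, and the only guide is that compound 3 sits at the limit. The expectation is a step that the limit leaves unreadable from compound 3 to compound 4 within scatter, most likely again a limit. Compound 4 is estimated at 80 ug/mL, range 32 ug/mL to 200 ug/mL.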

Compound 4, half-maximal cytotoxic concentration: > 64 ug/mL
Compound 4 gave a limit, no number (the forecaster's own chance of this, stated with the estimate: 70%); the middle value lies beyond the limit too.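

Compound 1, compound 3 and compound 4 all stop at a limit in this assay, so no step between them can be read: the limit of > 64 ug/mL in this assay, at which 3 of the 4 values shown sit.

The compounds shown leave open whether any group at this place on the shared core lowers tolerance to a readable value.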